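From Benzylcarbamoyl to 2,6-Dichlorobenzyl on Compound 1

The compounds below may be only part of what the source reports. "The series", "measured", "known", "first", "only" and "open" are said of these compounds alone.

Among the measured compounds shown here, compound 1 `COc1ccc(-c2cnc3nc(N)nc(N4CCN(C(=O)NCc5ccccc5)CC4)c3n2)cc1OC` is the only member of this small set with a numerical result: in a functional assay on cells (T-cell, Homo sapiens) for inhibition (a lower number here means a stronger inhibitor, a higher number a weaker inhibitor), compound 1 gives 18 nM. Compound 2 `CC(C)Oc1nc(N)nc2ncc(-c3ccc(C#N)cc3)nc12` reaches only a limit of the assay, > 10000 nM. Compound 3 `CCOc1nc(N)nc2ncc(-c3ccc(OC)cc3)nc12` likewise stops at a limit, > 10000 nM. Two of the three results are therefore (the limit of > 10000 nM in this assay, at which 2 of the 3 values shown sit), and compound 1 stands alone as a measured number. Compound 4 `COc1ccc(-c2cnc3nc(N)nc(N4CCN(Cc5c(Cl)cccc5Cl)CC4)c3n2)cc1OC` has not yet been measured; it differs from compound 1 in one place: 2,6-dichlorobenzyl in place of benzylcarbamoyl on an amine nitrogen in a ring. For the measured compounds named here, no step between measured compounds exists, so the size of such a change is untested here. In this assay compound 4 is expected to stay close to compound 1, within the scatter or somewhat weaker, at an estimated 40 nM (range 8 nM to 200 nM). That expectation corresponds to a 2.2-fold higher number from compound 1 to compound 4 (0.35 log units; beyond the scatter).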

Compound 4, half-maximal inhibitory concentration: 7600 nM
Compound 4: middle estimate off by 190-fold (2.28 log units), on the low side; measured number above the stated range.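

The first step read at this position shows that the group on this amine nitrogen can decide the result: replacing benzylcarbamoyl with 2,6-dichlorobenzyl gives, in this assay, a 420-fold higher number from compound 1 to compound 4 (2.63 log units; beyond the scatter). With the rest of the structure unchanged, this single change takes compound 4 close to the limit reached by compound 2 and compound 3: the limit of > 10000 nM in this assay, at which 2 of the 4 values shown sit.

Still open, going by these compounds, is whether the loss follows from removing the carbonyl and the amide hydrogen or from adding the two chlorines. An unsubstituted benzyl or an acetyl on the same nitrogen would help separate these.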